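Chloro to Fluoro on the Shared Core

The source may report more compounds than this note shows. Statements on the series, on what has been measured and on what is new or still open speak of the compounds shown alone.

Of the compounds shown here, three share one core and have been measured in an assay on isolated protein for inhibition of Amine oxidase [flavin-containing] A (Bos taurus); on this read-out lower numbers stand for stronger inhibition and higher numbers for weaker inhibition. Compound 1 `CCC(=O)N1N=C(c2ccccc2)CC1c1ccc(F)cc1` gives 7240 nM, compound 2 `CCC(=O)N1N=C(c2ccccc2)CC1c1ccc(C)cc1` gives 75900 nM, and compound 3 `CCC(=O)N1N=C(c2ccc(Cl)cc2)CC1c1ccc(Cl)cc1` gives 200 nM, the lowest of the three. Going by the values given here, the one single-point step, a 10-fold higher number from compound 1 to compound 2 (1.02 log units; beyond the scatter), concerns a methyl in place of fluoro and does not touch the change now considered. Compound 4 `CCC(=O)N1N=C(c2ccc(F)cc2)CC1c1ccc(Cl)cc1` differs from compound 3 by fluoro in place of chloro on an aromatic carbon. Among the compounds with values here, no measured pair bears directly on this exchange of one halogen for another; compounds 1 and 3 differ in two places. Compound 4 is therefore expected to give a somewhat higher number, a step of a 3.0-fold higher number from compound 3 to compound 4 (0.48 log units; beyond the scatter), estimated at 600 nM within 200 nM to 2000 nM.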

Compound 4, half-maximal inhibitory concentration: 1410 nM
Estimate against measurement, compound 4: 2.4-fold (0.37 log units) below, within the range that was stated.
By their numbers in this assay, from the lowest: compound 3; then compound 4; then compound 1; then compound 2.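

In this assay, going by these compounds alone, going from 4-chlorophenyl to 4-fluorophenyl gives a 7.1-fold higher number from compound 3 to compound 4 (0.85 log units; beyond the scatter), the first direct reading of this exchange, with the other 4-chlorophenyl group held unchanged. The position therefore distinguishes between these two halogens, and chloro goes with the lower number. Nothing available explains why the step has this direction or size. The compounds shown leave open how bromo, methoxy or an amine would read at this position. They also leave open whether the same exchange on the other 4-chlorophenyl group would give a similar step.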